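The source may hold more compounds than are shown below. What is called first, only, known or untested is meant among the compounds shown, and "the series" means these compounds.

Three esters of one shared core have been tested in a functional assay on MCF7 cells (Homo sapiens) for cytotoxicity; a higher number here means a weaker inhibitor, a lower number a stronger inhibitor. Compound 1 `CCCCCCCCCCCCCCCCCC(=O)Oc1ccc(/C=N/Cc2cccnc2)cc1` carries the longest chain of the three and in this assay gives "not active" (no number reported). Compound 2 `CCCCCCC(=O)Oc1ccc(/C=N/Cc2cccnc2)cc1` carries a much shorter chain and in this assay gives "not active" (no number reported). Compound 3 `CCCCCCCCCCCC(=O)Oc1ccc(/C=N/Cc2cccnc2)cc1` carries a chain of intermediate length and is the only one of the three for which a number was obtained: in this assay compound 3 gives 17600 nM, a weak result. Compound 2 therefore stands without a single number, and one further compound, compound 1, also stands without one; only compound 3 offers a number to hold anything against. Compound 4 `Oc1ccc(/C=N/Cc2cccnc2)cc1` keeps the same core but carries no ester at all. It differs from compound 2 by hydrogen in place of hexylcarbonyl on an oxygen on an aromatic ring. Among the compounds with values here, no measured pair differing in just one place exists in this set, so neither the size nor the direction of this step can be read off, and since compound 2 itself has no number, any expectation rests on compound 3 alone. The step is expected to leave potency weak, quite possibly again without a number, and compound 4 is estimated at 20000 nM, within a range from 5000 nM to 80000 nM.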

Compound 4, half-maximal inhibitory concentration: 12000 nM
The estimate for compound 4 lay 1.7-fold (0.22 log units) above the measured number; measured number inside the range.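

Compound 2 has no single number in this assay, and the change from compound 2 to compound 4 therefore cannot be read as a step. The compounds shown leave open what replacing hexylcarbonyl with hydrogen on that oxygen does to potency in this assay. Nothing shown here offers an explanation for the result of compound 4.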